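The source may report more compounds than this note shows. Statements on the series, on what has been measured and on what is new or still open speak of the compounds shown alone.

Measured so far in a functional assay on HL-60 cells (Homo sapiens) for antiproliferative activity, read by MTT assay; on this read-out higher numbers stand for weaker inhibition and lower numbers for stronger inhibition

compound 1 `O[C@@H]1[C@@H](O)[C@H](Cc2ccccc2)O[C@H](COCc2ccccc2)[C@H]1O` gives "not active" (no number reported)
compound 2 `O[C@@H]1[C@@H](OCc2ccccc2)[C@H](OCc2ccccc2)[C@@H](COCc2ccccc2)O[C@H]1Cc1ccccc1` gives 8700 nM
compound 3 `OC[C@H]1O[C@@H](Cc2ccccc2)[C@H](O)[C@@H](O)[C@@H]1OCc1ccccc1` gives "not active" (no number reported)

Compound 4 `O[C@@H]1[C@@H](O)[C@H](Cc2ccccc2)O[C@H](COCc2ccccc2)[C@H]1OCc1ccccc1` has not yet been measured.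

Compound 3 has no single number to its name, and compound 1 shares that standing. The structural change is benzyl in place of hydrogen on an oxygen on a saturated carbon and reads as hydroxymethyl to (benzyloxy)methyl. A step towards stronger inhibition is expected in this assay, though its size cannot be read from a starting point without a number. The expectation rests on compound 2 (8700 nM), which carries more benzyl groups than compound 4 and alone reaches a number. Another report without a number remains quite possible. For compound 4 the estimated value is 25000 nM, with an expected range from 10000 nM to 60000 nM.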

Compound 4, half-maximal inhibitory concentration: 26600 nM
Estimate against measurement, compound 4: 1.1-fold (0.03 log units) below; the range from low to high includes it.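

In this assay compound 3 is reported as "not active" (no number reported), whereas benzyl on the oxygen of its hydroxymethyl group gives compound 4 a measurable value, though the size of this step cannot be read. Benzyl in this place is therefore compatible with a numerical result, and hydrogen in place of a further benzyl gives a 3.1-fold higher number from compound 2 to compound 4 (0.49 log units; beyond the scatter), a modest step beyond the scatter. No evidence is available to explain either change. The compounds shown leave open whether an amine or a carboxylic acid on this oxygen would also give a number.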